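The source may hold more compounds than are shown below. What is called first, only, known or untested is meant among the compounds shown, and "the series" means these compounds.

Compound 1 `CC(C)(C)C1=NN(c2ccc(F)cc2)C(c2ccc(O)cc2)C1` and compound 2 `CC(C)(C)C1=NN(c2ccc(F)cc2F)C(c2ccc(O)cc2)C1` share one core, and the step from one to the other is a fluoro in place of hydrogen on an aromatic carbon. In an assay on isolated protein for inhibition of protein kinase C zeta type (Homo sapiens), with a stated time of 4 min, tested at 62.5 uM (a lower number here means less inhibition, a higher number more inhibition at the concentration tested (going by the name of the read-out)), compound 1 gives 95.5%, while compound 2 gives 68%, so compound 2 stands lowest of the two measured numbers, and that step amounts to a number 27.5 percentage points lower from compound 1 to compound 2 (beyond the scatter). Compound 3 `Cc1ccc(N2N=C(C(C)(C)C)CC2c2ccc(O)cc2)c(C)c1` has not yet been measured. It differs from compound 2 by 2,4-dimethylphenyl in place of 2,4-difluorophenyl on an amine nitrogen in a ring. Among the compounds with values here, the only measured step, a number 27.5 percentage points lower from compound 1 to compound 2 (beyond the scatter), concerns a different kind of change and so bears on this one only loosely. The measured numbers give no direct reading for methyl groups in this place, so the expected step of a number 7 percentage points higher from compound 2 to compound 3 (within the scatter) is estimated with little confidence in either direction. Compound 3 is expected to give about 75%, within a range from 45% to 98%.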

Compound 3, a percentage reported as inhibition, at one concentration (the size of the read-out at that concentration, not a potency): 59.9%
The estimate for compound 3 lay 15.1 percentage points above the measured number, and the stated range covers the measured number.
By their numbers in this assay, from the lowest: compounds 3 and 2 (each within the scatter of the next); then compound 1.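

In this assay, exchanging 2,4-difluorophenyl for 2,4-dimethylphenyl on the amine nitrogen in the ring gives a number 8.1 percentage points lower from compound 2 to compound 3 (within the scatter) and so does not separate these two groups at this position. Set against 4-fluorophenyl, the 2,4-dimethylphenyl group gives a number 35.6 percentage points lower from compound 1 to compound 3 (beyond the scatter) in the same assay. The lower reading seen with 2,4-difluorophenyl is therefore not confined to a fluorine-bearing ring here, since both 2,4-substituted rings among these three compounds read lower than the 4-fluorophenyl ring, but nothing available explains this.

On these data alone, it remains open whether 4-methylphenyl would read like compound 1 or like compound 3, which would show whether methyl and fluoro also match when only one is present. As far as these compounds go, how 2,4-dichlorophenyl or a ring carrying an amine would read at this position is also open.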